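The source may report more compounds than this note shows. Statements on the series, on what has been measured and on what is new or still open speak of the compounds shown alone.

Measured compounds:
- compound 1 `CCCCC(O)c1ccc(CN(CCCCCCC(=O)O)S(C)(=O)=O)cc1`: > 3200 nM
- compound 2 `CC(C)(C)c1ccc(CN(Cc2cccc(CCC(=O)O)c2)S(=O)(=O)c2nccs2)cc1`: > 3200 nM

In an assay on HEK293 cells for inhibition of prostaglandin E2 receptor EP4 subtype (Rattus norvegicus) (on this read-out lower numbers stand for stronger inhibition and higher numbers for weaker inhibition), compound 2 gives only a limit, > 3200 nM, and no number. In this assay compound 1 likewise returns a limit, > 3200 nM. Going by the values given here, both results rest at the limit of > 3200 nM in this assay, at which 2 of the 2 values shown sit, so no step between two measured compounds can be read from them; only what each value shows is known.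

Compound 3 `CC(C)(C)c1ccc(CN(Cc2cccc(CCC(=O)O)c2)S(=O)(=O)c2ccccn2)cc1` differs from compound 2 in one place: pyridin-2-yl in place of 1,3-thiazol-2-yl on a sulfonyl sulfur. Nothing measured here tells how this change moves the read-out, and with both neighbours sitting at the limit there is no direction to lean on. The expected step is a step that the limit leaves unreadable from compound 2 to compound 3, that is, nothing beyond the usual scatter. Compound 3 is therefore expected to give 5000 nM, somewhere between 1500 nM and 20000 nM, with a fair chance that this assay again reports only a limit.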

Compound 3, half-maximal inhibitory concentration: > 3200 nM
Compound 3 ended at the assay's limit (the forecaster's own chance of this, stated with the estimate: 70%); the middle value does not contradict the limit.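

In this assay compound 2 and compound 3 both return only a limit, so no step between them can be read: the limit of > 3200 nM in this assay, at which 3 of the 3 values shown sit.

The compounds shown leave open whether pyridin-2-yl in place of 1,3-thiazol-2-yl on a sulfonyl sulfur moves the read-out at all.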